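The compounds below may be only part of what the source reports. "The series", "measured", "known", "first", "only" and "open" are said of these compounds alone.

Compound 1 `Cc1cc(SC(C)(C)C)c(S(C)(=O)=O)cc1C(=O)N=C(N)N` gives 22 nM in a functional assay for inhibition of sodium/hydrogen exchanger (Oryctolagus cuniculus); a higher number here means a weaker inhibitor, a lower number a stronger inhibitor.
Compound 2 `CCOc1cc(C)c(C(=O)N=C(N)N)cc1S(C)(=O)=O` gives 19 nM in this assay.
Compound 3 `Cc1c(C(=O)N=C(N)N)cc(S(C)(=O)=O)cc1-n1cccc1` gives 100 nM in this assay.

Compound 3 stands highest of the three numbers, beyond the scatter from compound 1 and from compound 2, and is therefore the weakest inhibitor of the set in this assay. Among the measured compounds shown here, the only single-point step among the measured compounds, a 1.2-fold lower number from compound 1 to compound 2 (0.06 log units; within the scatter), concerns an exchange at a different position and lies within the scatter, so it shows that one such swap left this assay essentially unchanged, but it does not bear directly on the change now considered.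

Compound 4 `Cc1ccc(S(C)(=O)=O)cc1C(=O)N=C(N)N` differs from compound 3 by hydrogen in place of 1H-pyrrol-1-yl on an aromatic carbon. For the measured compounds named here, no measured pair isolates this change, and compounds 1 and 2 carry their extra groups elsewhere on the shared core, so their values give only a rough reference for a compound lacking the pyrrolyl. Since compound 3 gives 100 nM and both smaller analogues sit well below it, compound 4 is expected to move towards them, with a 2.0-fold lower number from compound 3 to compound 4 (0.30 log units; within the scatter). Compound 4 is therefore estimated at 50 nM, with a range from 15 nM to 200 nM.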

Compound 4, half-maximal inhibitory concentration: 150 nM
Compound 4: the middle estimate sits 3.0-fold (0.48 log units) below what was measured; measured number inside the range.
By their numbers in this assay, from the lowest: compounds 2 and 1 (each within the scatter of the next); then compounds 3 and 4 (each within the scatter of the next).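

With hydrogen in place of 1H-pyrrol-1-yl on the aromatic carbon ortho to the methyl group, this assay shows a 1.5-fold higher number from compound 3 to compound 4 (0.18 log units; within the scatter), so this large aromatic ring and a bare hydrogen cannot be told apart at this position, and the pyrrolyl group neither gains nor loses anything measurable. Compound 4 also serves as the unsubstituted reference for the groups placed elsewhere on the shared core: hydrogen in place of ethoxy gives a 7.9-fold higher number from compound 2 to compound 4 (0.90 log units; beyond the scatter), and hydrogen in place of (tert-butyl)sulfanyl gives a 6.8-fold higher number from compound 1 to compound 4 (0.83 log units; beyond the scatter), so those two groups are each tied to a clearly lower number, which the pyrrolyl group at its own position is not. Nothing available explains either outcome.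

The compounds shown test only one group on the carbon ortho to the methyl group, so it remains open whether an amine, a methoxy group, a carboxylic acid or a longer alkyl chain there would move the number beyond the scatter. Going by these compounds, it also remains open whether ethoxy or (tert-butyl)sulfanyl would give the same lower number on that carbon as at their own position.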